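Halogen pattern on the benzyl ether and receptor affinity

This account rests on a few compounds, and the source may have more. Where it says the series, first, only, none or still open, it means among the compounds named here.

Compound 1 `N[C@]1(C(=O)O)[C@H]2[C@@H](C[C@H]1OCc1cccc(Br)c1)[C@]2(F)C(=O)O` and compound 2 `N[C@]1(C(=O)O)[C@H]2[C@@H](C[C@H]1OCc1cc(Cl)ccc1Cl)[C@]2(F)C(=O)O` share one core and differ only in the aryl group on the benzyl ether. In an assay on CHO cells for binding affinity to metabotropic glutamate receptor 2 (Rattus norvegicus) (a higher number here means a weaker inhibitor, a lower number a stronger inhibitor), compound 1 gives 4.71 nM, while compound 2 gives 11.8 nM; after the step of a 2.5-fold higher number from compound 1 to compound 2 (0.40 log units; beyond the scatter), compound 2 holds the higher of the two numbers. Compound 3 `N[C@]1(C(=O)O)[C@H]2[C@@H](C[C@H]1OCc1ccc(F)c(Cl)c1)[C@]2(F)C(=O)O` is the next variant: 3-chloro-4-fluorophenyl in place of 2,5-dichlorophenyl on a saturated chain carbon bound to an oxygen on a saturated carbon. Within the data shown here, no measured step covers this exact exchange; only the move from compound 1 to compound 2 bears on it, and it shifted the number modestly, beyond the scatter. The halogen pattern of compound 3 matches neither compound 2 nor compound 1, so that sole step is only a rough guide. A modest move back toward the number of compound 1 is expected for compound 3, giving a 1.8-fold lower number from compound 2 to compound 3 (0.26 log units; within the scatter). Compound 3 is therefore estimated at 6.5 nM, between 2.5 nM and 17 nM in this assay.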

Compound 3, inhibition constant: 3.57 nM
Estimate against measurement, compound 3: 1.8-fold (0.26 log units) above, within the range that was stated.
By their numbers in this assay, from the lowest: compounds 3 and 1 (each within the scatter of the next); then compound 2.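

In this assay the change away from the 2,5-dichlorophenyl group gives a 3.3-fold lower number from compound 2 to compound 3 (0.52 log units; beyond the scatter) and so lowers the number by a step beyond the scatter, which shows that this position on the benzyl ether responds to a change of halogen pattern in both directions. The exchange of the 3-bromophenyl group for the 3-chloro-4-fluorophenyl group gives a 1.3-fold lower number from compound 1 to compound 3 (0.12 log units; within the scatter) and stays within the scatter, so these two groups cannot be told apart here, and among the three compounds only compound 2 stands apart. Nothing at hand explains why the 2,5-dichlorophenyl group differs from the other two.

On these data alone, it remains open how a methoxy group or a nitrile on the phenyl ring would compare with these halogens. A 2,5-difluorophenyl group would bear on whether the higher number of compound 2 follows the pattern of substitution or the chlorine atoms themselves.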